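Ring expansion on the amide side chain of compound 2

This account rests on a few compounds, and the source may have more. Where it says the series, first, only, none or still open, it means among the compounds named here.

The shared core is carried by compound 1 `CC/C=C/C(=O)Nc1cc2c(N3CCc4ccccc43)ncnc2cc1OC` and compound 2 `COc1cc2ncnc(N3CCc4ccccc43)c2cc1NC(=O)/C=C/CN1CCCC1`. In a functional assay on A549 cells (Homo sapiens) for antiproliferative activity, read by MTT assay, with a stated time of 72 h (on this read-out higher numbers stand for weaker inhibition and lower numbers for stronger inhibition), compound 1 gives 2470 nM, while compound 2 gives 1210 nM. Of these two numbers, compound 2 holds the lower, and its nearest neighbour lies beyond the scatter, as the step of a 2.0-fold lower number from compound 1 to compound 2 (0.31 log units; beyond the scatter) shows. Compound 3 `COc1cc2ncnc(N3CCc4ccccc43)c2cc1NC(=O)/C=C/CN1CCCCC1` has not yet been measured. It differs from compound 2 by piperidin-1-yl in place of pyrrolidin-1-yl on a saturated chain carbon bound to a double-bonded chain carbon. Among the compounds with values here, no measured pair repeats this exact exchange; the only step on record, a 2.0-fold lower number from compound 1 to compound 2 (0.31 log units; beyond the scatter), concerns the entry of the pyrrolidin-1-yl group at this same place in place of methyl and was modest in size. It shows that a ring at this position makes a difference, but it says nothing about swapping one such ring for the next larger one. The expectation for compound 3 in this assay is therefore a number close to that of compound 2, with the step of a 1.2-fold lower number from compound 2 to compound 3 (0.08 log units; within the scatter) expected to remain within the usual scatter. Compound 3 is estimated at 1000 nM, with a range from 400 nM to 2500 nM.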

Compound 3, half-maximal inhibitory concentration: 2540 nM
Beside the measured number, compound 3's estimate is 2.5-fold (0.40 log units) below it; the measured number lies above the stated range.
By their numbers in this assay, from the lowest: compound 2; then compounds 1 and 3 (each within the scatter of the next).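

In this assay the size of the ring on this saturated chain carbon matters: piperidin-1-yl in place of pyrrolidin-1-yl gives a 2.1-fold higher number from compound 2 to compound 3 (0.32 log units; beyond the scatter) and so runs against the earlier 2.0-fold lower number from compound 1 to compound 2 (0.31 log units; beyond the scatter) in direction. Piperidin-1-yl in place of methyl gives a 1.0-fold higher number from compound 1 to compound 3 (0.01 log units; within the scatter) and therefore brings no change that can be told from the scatter. The earlier gain thus cannot be credited to a ring at this place as such, since among the compounds shown it goes with pyrrolidin-1-yl and not with piperidin-1-yl.

From the compounds shown here alone, nothing available here accounts for how a ring of one more carbon produces this difference in cell growth inhibition, so the reason remains unknown. Going by these compounds, it also remains open whether an azetidin-1-yl ring, a dimethylamino group or a morpholin-4-yl ring on the same carbon would fall with compound 2 or with the other two compounds, and so whether pyrrolidin-1-yl is an isolated case or part of a wider trend.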